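This account rests on a few compounds, and the source may have more. Where it says the series, first, only, none or still open, it means among the compounds named here.

Measured compounds:
- compound 1 `C=C1CC[C@@H](C(C)C)[C@]12CC=C(C=O)CC2`, 210000 nM
- compound 2 `CC1(C)CCCC2=CC=C(C=O)CC[C@]21C`, 167000 nM

Both were tested in a functional assay on MCF7 cells (Homo sapiens) for cytotoxicity, read by MTT assay, with a stated time of 48 h; on this read-out higher numbers stand for weaker inhibition and lower numbers for stronger inhibition. Compound 1 has the larger of the two numbers, but the gap to compound 2 lies within the usual scatter, so the two cannot be told apart. Compound 3 `C#CC1=CC[C@]2(CC1)C(=C)CC[C@H]2C(C)C` has not yet been measured. It differs from compound 1 in one place: ethynyl in place of formyl on a double-bonded ring carbon. Among the measured compounds shown here, no step between measured compounds is known here, so nothing shows how this change acts; in this assay I expect no step beyond the scatter, or at most a small move toward a higher number. Compound 3 is therefore expected to give about 250000 nM, between 80000 nM and 600000 nM. This expectation amounts to a step of a 1.2-fold higher number from compound 1 to compound 3 (0.08 log units; within the scatter).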

Compound 3, half-maximal inhibitory concentration: 135000 nM
Compound 3: middle estimate off by 1.9-fold (0.27 log units), on the high side; low and high end bracket the measured number.
By their numbers in this assay, from the lowest: compounds 3, 2 and 1 (each within the scatter of the next).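

In this assay, putting ethynyl in place of formyl on this double-bonded ring carbon gives a 1.6-fold lower number from compound 1 to compound 3 (0.19 log units; within the scatter) and so does not separate the two groups. In this one pair, the hydrogen-bond acceptor counted on formyl can go without a shift beyond the scatter. No measurement given here offers an explanation for this result. From the compounds shown here alone, whether an amine or a carboxylic acid at this position would shift the number beyond the scatter remains open. So does whether the same exchange would behave alike on the core of compound 2.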